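The source may hold more compounds than are shown below. What is called first, only, known or untested is meant among the compounds shown, and "the series" means these compounds.

In a functional assay on MCF7 cells (Homo sapiens) for inhibition, with a stated time of 96 h (a higher number here means a weaker inhibitor, a lower number a stronger inhibitor), the measured compounds are:
- Compound 1 `COc1cc(C(=O)c2cn(-c3ccc(C)cc3)cc2-c2ccoc2)cc(OC)c1OC` gives 18 nM
- Compound 2 `COc1cc(C(=O)c2cn(-c3ccc(F)cc3)cc2-c2ccoc2)cc(OC)c1OC` gives 15 nM

Compound 2 stands level with compound 1, since a 1.2-fold lower number from compound 1 to compound 2 (0.08 log units; within the scatter) is a step of fluoro in place of methyl on an aromatic carbon. Compound 3 `COc1cc(C(=O)c2cn(-c3ccc(F)cc3)cc2-c2cccnc2)cc(OC)c1OC` has pyridin-3-yl in place of furan-3-yl on an aromatic carbon and keeps the 4-fluorophenyl group. Among the measured compounds shown here, no measured step touches this place, so the only step available bears on it weakly. A modest rise in the number is expected, tentatively, as a 2.7-fold higher number from compound 2 to compound 3 (0.43 log units; beyond the scatter) in this estimate. Compound 3 is expected at 40 nM with an estimated range from 12 nM to 150 nM in this assay here.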

Compound 3, half-maximal inhibitory concentration: 39 nM
Compound 3: the middle estimate sits 1.0-fold (0.01 log units) above what was measured, within the range that was stated.
By their numbers in this assay, from the lowest: compounds 2 and 1 (each within the scatter of the next); then compound 3.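

In this assay, pyridin-3-yl in place of furan-3-yl gives a 2.6-fold higher number from compound 2 to compound 3 (0.41 log units; beyond the scatter) with the 4-fluorophenyl group kept, so this position, unlike the aromatic carbon changed from compound 1 to compound 2, answers to a single change with a step beyond the scatter. Nothing available explains why the six-membered ring gives the higher number. Still open, from the compounds shown here alone, is how a thiophen-3-yl group or an aminomethyl group would read at this position, and whether the step from furan-3-yl to pyridin-3-yl stays the same with the methyl group of compound 1 in place of fluoro.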